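Methyl in place of phenyl on a carbonyl carbon

A few compounds are considered here, and "the series" means these few. Any claim that something is new, unique, unknown or untested is made for them only; others in the source may bear on it.

Of the compounds shown here, three have been measured so far. Compound 1 `CC(=O)NC(=S)Nc1ccc(Br)c2ccccc12` and compound 3 `O=C(NC(=S)Nc1ccc(Br)c2ccccc12)c1ccccc1` share one core, while compound 2 `COc1cc(C)ccc1NC(=S)NC(=O)c1ccccc1` carries a different core; how the core of compound 2 differs from that of compound 3 is not broken down here. In an assay for inhibition of epoxide hydrolase 1 (Homo sapiens), read by fluorescence, using microsomes (on this read-out higher numbers stand for weaker inhibition and lower numbers for stronger inhibition), compound 3 gives 1880 nM, compound 1 gives 2420 nM and compound 2 gives 2540 nM. All three numbers sit close together, and none of the gaps between them reaches beyond the scatter of repeated measurements, so no ordering among them can be claimed.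

For the measured compounds named here, the one single-point change available within the measured set is methyl in place of phenyl on a carbonyl carbon, a step that produced a 1.3-fold higher number from compound 3 to compound 1 (0.11 log units; within the scatter).

Compound 4 `COc1cc(C)ccc1NC(=S)NC(C)=O` has not yet been measured. It arises from compound 2 by methyl in place of phenyl on a carbonyl carbon, the same change as from compound 3 to compound 1, made at the same kind of place on the other core. Going by the values given here, with only one earlier example of this change, and that one within the scatter, the expectation for compound 4 rests on carrying the earlier step over: the estimated step is a 1.3-fold higher number from compound 2 to compound 4 (0.11 log units; within the scatter), in line with what was seen from compound 3 to compound 1 (a 1.3-fold higher number from compound 3 to compound 1 (0.11 log units; within the scatter)). On that basis compound 4 is expected to give about 3300 nM in this assay, most likely between 1700 nM and 6500 nM.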

Compound 4, half-maximal inhibitory concentration: 1690 nM
Compound 4: middle estimate off by 2.0-fold (0.29 log units), on the high side; the measured number lies below the stated range.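

In this assay, methyl in place of phenyl on a carbonyl carbon gave a 1.5-fold lower number from compound 2 to compound 4 (0.18 log units; within the scatter). Set beside the earlier example, the two steps point in opposite directions on paper, but they do not differ by more than repeated measurement would allow: the same change on two cores in this assay, a 1.3-fold higher number (0.11 log units; within the scatter) from compound 3 to compound 1 and a 1.5-fold lower number (0.18 log units; within the scatter) from compound 2 to compound 4, 1.9-fold (0.29 log units) apart, within the scatter of two such steps. This shows that, in both pairs, swapping phenyl for methyl at this place leaves the number within the scatter, so the large group can be replaced by the small one on either core without a readable step; it does not show that the change has a direction of its own, that the two cores respond differently, or that the same would hold on any other core in the series.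

Only phenyl and methyl stand on this carbonyl carbon among the compounds shown, so it remains open whether a longer chain, a cyclohexyl ring or a chain ending in an amine would move the number beyond the scatter. As far as these compounds go, it also remains open whether a change elsewhere on either core, such as a carboxylic acid in place of the bromine of compound 1, would produce a step that can be read at all.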